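The source may hold more compounds than are shown below. What is called first, only, known or untested is meant among the compounds shown, and "the series" means these compounds.

Compound 1 `OCCOCn1c(Cl)nc2c(Cl)c(Cl)ccc21` was tested in a functional assay on KB cells (Homo sapiens) for inhibition; a higher number here means a weaker inhibitor, a lower number a stronger inhibitor. In this assay compound 1 gives > 100000 nM, which is a limit of the assay rather than a measured number. Compound 2 `CNc1nc2cc(Cl)c(Cl)cc2n1COCCO` likewise shows only > 100000 nM, again a limit. Compound 3 `CN(C)c1nc2cc(Cl)c(Cl)cc2n1COCCO` also returns > 100000 nM, a limit as well. Among the measured compounds shown here, the single step among the measured compounds, a step that the two limits leave unreadable from compound 2 to compound 3, cannot be read because of the limit of > 100000 nM in this assay, at which 3 of the 3 values shown sit. Compound 4 `OCCOCn1c(SCc2ccccc2)nc2c(Cl)c(Cl)ccc21` differs from compound 1 by benzylsulfanyl in place of chloro on an aromatic carbon. For the measured compounds named here, no measured step bears on this change, and compound 1 itself offers no number to start from, so no step beyond the scatter can be predicted either way. Compound 4 is therefore expected to stay weak, estimated near 60000 nM within 8000 nM to 300000 nM. The expected step is then an at least 1.6-fold lower number from compound 1 to compound 4 (0.22 log units; that floor lies within the scatter).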

Compound 4, half-maximal inhibitory concentration: 35000 nM
The estimate for compound 4 lay 1.7-fold (0.23 log units) above the measured number; low and high end bracket the measured number.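

In this assay, benzylsulfanyl in place of chloro on this aromatic carbon, between two ring nitrogen atoms, gives an at least 2.8-fold lower number from compound 1 to compound 4 (0.45 log units; beyond the scatter). Among the compounds shown here, this is the first change whose size has a readable floor, and it shows that this carbon can carry a group of 8 heavy atoms with inhibition still measurable.

On these data alone, compound 1 stands only at a limit, so the full size of the step stays open because of it: the limit of > 100000 nM in this assay, at which 3 of the 4 values shown sit. Whether a smaller methylsulfanyl group or an amine on this carbon would also give a measurable number remains open as well.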